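Notes on the ring-nitrogen group in the shared core

A few compounds are considered here, and "the series" means these few. Any claim that something is new, unique, unknown or untested is made for them only; others in the source may bear on it.

Measured so far in a functional assay on isolated protein for inhibition of Glucose-dependent insulinotropic receptor (Rattus norvegicus), read by HTRF and cAMP accumulation; a lower number here means that less compound is needed, a higher number that more compound is needed for the effect:
compound 1 `Cc1nc(S(C)(=O)=O)ccc1Oc1ncnc(OC2CCN(C(=O)OC(C)C)CC2)c1F` gives 142 nM
compound 2 `Cc1nc(S(C)(=O)=O)ccc1Oc1ncnc(OC2CCN(C(=O)SC3CC3)CC2)c1F` gives 126 nM
compound 3 `Cc1nc(S(C)(=O)=O)ccc1Oc1ncnc(OC2CCN(C(=S)OC(C)C)CC2)c1F` gives 1050 nM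

Compound 3 stands highest of the three numbers. Its nearest neighbour is compound 1, with a 7.4-fold higher number from compound 1 to compound 3 (0.87 log units; beyond the scatter); the furthest is compound 2, with an 8.3-fold higher number from compound 2 to compound 3 (0.92 log units; beyond the scatter). Between compound 1 and compound 2 the change is a 1.1-fold lower number from compound 1 to compound 2 (0.05 log units; within the scatter).

Compound 4 `Cc1nc(S(C)(=O)=O)ccc1Oc1ncnc(OC2CCN(C(=O)c3nc(C(C)(C)F)no3)CC2)c1F` carries a group of 11 heavy atoms (6 carbon, 2 nitrogen, 2 oxygen, 1 fluorine; one five-membered aromatic ring with 3 hetero atoms) in place of a group of 6 heavy atoms (4 carbon, 1 oxygen, 1 sulfur; no ring), on an amine nitrogen in a ring. For the measured compounds named here, no measured step covers this replacement itself. What the measurements do show is that the group on the ring nitrogen of compound 3, which has a sulfur where the group of compound 1 has an oxygen, is the only one of the three that gave a clearly higher number, through a 7.4-fold higher number from compound 1 to compound 3 (0.87 log units; beyond the scatter) and an 8.3-fold higher number from compound 2 to compound 3 (0.92 log units; beyond the scatter). Compound 4 has a group with two oxygens and a carbonyl again, though a larger one with an aromatic ring, and what that ring adds cannot be read from the three compounds. The working expectation is a return toward the range of compound 1 and compound 2, so a lower number, with an expected step of a 6.6-fold lower number from compound 3 to compound 4 (0.82 log units; beyond the scatter). For compound 4 the estimate in this assay is 160 nM, expected to fall between 50 nM and 600 nM.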

Compound 4, half-maximal effective concentration: 606 nM
Beside the measured number, compound 4's estimate is 3.8-fold (0.58 log units) below it; the measured number lies above the stated range.
By their numbers in this assay, from the lowest: compounds 2 and 1 (each within the scatter of the next); then compounds 4 and 3 (each within the scatter of the next).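

Notes on what compound 4 adds

In this assay, the group with the five-membered aromatic ring with 3 hetero atoms does not separate from the group of 6 heavy atoms it replaces on the ring nitrogen, with a 1.7-fold lower number from compound 3 to compound 4 (0.24 log units; within the scatter) lying within the scatter. A carbonyl on the ring nitrogen therefore does not by itself hold the number in the range of the two carbonyl compounds, as shown by a 4.3-fold higher number from compound 1 to compound 4 (0.63 log units; beyond the scatter) and by a 4.8-fold higher number from compound 2 to compound 4 (0.68 log units; beyond the scatter), both beyond the scatter. The earlier compounds shown here showed a clear step only on replacing the carbonyl oxygen with sulfur, whereas this position also responds to the group on the carbonyl carbon, although not to every change there, since a 1.1-fold lower number from compound 1 to compound 2 (0.05 log units; within the scatter) stays within the scatter. No measurement available here accounts for this result.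

On these data alone, whether the step follows the aromatic ring itself, the fluorine, or the larger group as a whole remains open. A methyl group in place of the fluorine-bearing alkyl group on that ring, or a dimethylamino group on the carbonyl carbon, would help to separate these readings.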